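This account rests on a few compounds, and the source may have more. Where it says the series, first, only, none or still open, it means among the compounds named here.

Measured compounds:
Compound 1, `CC(=O)Oc1cc(Cl)ccc1C(=O)Nc1ncc([N+](=O)[O-])s1` — 83.5%
Compound 2, `O=C(Nc1ncc([N+](=O)[O-])s1)c1cc(Cl)ccc1O` — 63%
Compound 3, `CC(=O)Oc1ccc(Cl)cc1C(=O)Nc1ncc([N+](=O)[O-])s1` — 31.2%

In an ADME assay on HEK-293T cells (Homo sapiens) for cytotoxicity, read by MTT assay, tested at 100 uM (a higher number here means a weaker effect of the compound at the concentration tested, a lower number a stronger effect), compound 3 stands lowest of the three numbers: compound 2 lies a number 31.8 percentage points lower from compound 2 to compound 3 (beyond the scatter) removed from it, and compound 1 gives 83.5%, further still from the value of compound 3. Among the measured compounds shown here, the one single-place step that the data hold is the acetyl in place of hydrogen between compound 2 and compound 3, a large step of a number 31.8 percentage points lower from compound 2 to compound 3 (beyond the scatter).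

Compound 4, `CC(=O)Oc1c(Cl)cc(Cl)cc1C(=O)Nc1ncc([N+](=O)[O-])s1`, differs from compound 3 by chloro in place of hydrogen on an aromatic carbon. For the measured compounds named here, none of the measured steps adds a chloro group, so no step bears directly on this change, and the only guide is the starting point given by the value of compound 3 in this assay. With nothing in the data pointing in either direction, a step of no more than the usual scatter is expected, with a wide range on either side. For compound 4 in this assay the estimated value is therefore 35%, between 12% and 65%, which means an expected step of a number 3.8 percentage points higher from compound 3 to compound 4 (within the scatter).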

Compound 4, a percentage reported as activity, at one concentration (the size of the read-out at that concentration, not a potency): 95.1%
For compound 4 the middle estimate is 60.1 percentage points below the measured one, outside the stated range (above it).
By their numbers in this assay, from the lowest: compound 3; then compound 2; then compound 1; then compound 4.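

In this assay, chloro in place of hydrogen on an aromatic carbon, ortho to an acetoxy group, gives a number 63.9 percentage points higher from compound 3 to compound 4 (beyond the scatter), so a single added chlorine at this place is enough to shift the read-out strongly towards a weaker effect. Among the compounds shown here, the only earlier single-place step, the acetyl in place of hydrogen on an oxygen, gave a number 31.8 percentage points lower from compound 2 to compound 3 (beyond the scatter), so the shared core is now seen to respond in both directions, depending on the place changed. The data at hand offer no explanation of why this one atom changes the read-out so much.

On these data alone, it remains open whether this shift belongs to chloro itself or would also appear with a methyl group, a methoxy group or an amine at this place. Also open, as far as these compounds go, is whether the same chloro would produce a similar step when the acetoxy group is replaced by a free hydroxyl group.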